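From 2,4,5-trichlorophenyl to 3,5-difluorophenyl on an amide-type nitrogen

The source may report more compounds than this note shows. Statements on the series, on what has been measured and on what is new or still open speak of the compounds shown alone.

Compound 1 `COc1cc(Nc2ncnc3c(NC(=O)Nc4ccc(C)cc4C)cccc23)cc(OC)c1` gives 1290 nM
Compound 2 `COc1cc(Nc2ncnc3c(NC(=O)Nc4cc(Cl)cc(Cl)c4)cccc23)cc(OC)c1` gives 30.2 nM
Compound 3 `COc1cc(Nc2ncnc3c(NC(=O)Nc4cc(Cl)c(Cl)cc4Cl)cccc23)cc(OC)c1` gives 4890 nM

In a functional assay on RT-112 cells (Homo sapiens) for antiproliferative activity, read by MTT assay, with a stated time of 72 h (on this read-out lower numbers stand for stronger inhibition of growth and higher numbers for weaker inhibition of growth), compound 3 gives the highest number of the three (4890 nM). Compound 4 `COc1cc(Nc2ncnc3c(NC(=O)Nc4cc(F)cc(F)c4)cccc23)cc(OC)c1` carries 3,5-difluorophenyl in place of 2,4,5-trichlorophenyl on an amide-type nitrogen. The measured step closest to this change is a 160-fold higher number from compound 2 to compound 3 (2.21 log units; beyond the scatter) and it is large, while a 3.8-fold higher number from compound 1 to compound 3 (0.58 log units; beyond the scatter) is modest. The closest measured group to 3,5-difluorophenyl is the 3,5-dichlorophenyl of compound 2 (30.2 nM), so compound 4 is expected to lie much nearer that value. Among the measured compounds shown here, no measured compound carries fluorine, which keeps the range wide. In this assay the expected change is a 49-fold lower number from compound 3 to compound 4 (1.69 log units; beyond the scatter) and thus large, towards a lower number. Compound 4 is therefore estimated at 100 nM (expected range 25 nM to 450 nM).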

Compound 4, concentration for 50% growth inhibition: 2630 nM
Beside the measured number, compound 4's estimate is 26-fold (1.42 log units) below it, and the stated range ends below it.
By their numbers in this assay, from the lowest: compound 2; then compound 1; then compounds 4 and 3 (each within the scatter of the next).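

With 3,5-difluorophenyl in place of 3,5-dichlorophenyl on the amide-type nitrogen, this assay gives an 87-fold higher number from compound 2 to compound 4 (1.94 log units; beyond the scatter), so the low number of compound 2 does not carry over from 3,5-dichlorophenyl to 3,5-difluorophenyl. The other two steps put compound 4 with the weaker compounds: a 1.9-fold lower number from compound 3 to compound 4 (0.27 log units; within the scatter), and a 2.0-fold higher number from compound 1 to compound 4 (0.31 log units; beyond the scatter). Nothing shown here accounts for the gap between the chlorine and fluorine pair. The compounds shown leave open where 3,5-dibromophenyl or 3,5-dimethylphenyl would fall, and so whether 3,5-dichlorophenyl stands alone at this position.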